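The source may report more compounds than this note shows. Statements on the series, on what has been measured and on what is new or still open speak of the compounds shown alone.

Three compounds have so far been measured in a functional assay on BXPC-3 cells (Homo sapiens) for inhibition, read by MTT assay, with a stated time of 72 h; on this read-out higher numbers stand for weaker inhibition of growth and lower numbers for stronger inhibition of growth:

Compound 1, `O=S(=O)(NCCCNCc1ccc(Cl)cc1)c1cc(C(F)(F)F)cc(C(F)(F)F)c1`, gives 1600 nM.
Compound 2, `CC(C)(C)c1ccc(CNCCCNS(=O)(=O)c2cc(C(F)(F)F)cc(C(F)(F)F)c2)cc1`, gives 1400 nM.
Compound 3, `O=S(=O)(NCCCNCc1ccccc1Cl)c1cc(C(F)(F)F)cc(C(F)(F)F)c1`, gives 11000 nM.

Among these three numbers compound 1 stands second highest. The step of a 1.1-fold lower number from compound 1 to compound 2 (0.06 log units; within the scatter) lies within the scatter, whereas the step of a 6.9-fold higher number from compound 1 to compound 3 (0.84 log units; beyond the scatter) lies beyond it. Compound 4, `COc1ccccc1CNCCCNS(=O)(=O)c1cc(C(F)(F)F)cc(C(F)(F)F)c1`, has not yet been measured. It differs from compound 1 in one place: 2-methoxyphenyl in place of 4-chlorophenyl on a saturated chain carbon bound to an amine nitrogen. For the measured compounds named here, the steps that bear on this change both move a substituent to the 2-position of the benzyl ring: a 6.9-fold higher number from compound 1 to compound 3 (0.84 log units; beyond the scatter) and a 7.9-fold higher number from compound 2 to compound 3 (0.90 log units; beyond the scatter). Going by the values given here, both point toward weaker growth inhibition, so a higher number in this assay is expected, although no measured pair tells how a 2-methoxyphenyl compares with a 2-chlorophenyl. Compound 4 is therefore estimated at 6500 nM, a step of a 4.1-fold higher number from compound 1 to compound 4 (0.61 log units; beyond the scatter), with a range from 2500 nM to 17000 nM.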

Compound 4, concentration for 50% growth inhibition: 1700 nM
Compound 4: the middle estimate sits 3.8-fold (0.58 log units) above what was measured; the whole stated range lies above it.
By their numbers in this assay, from the lowest: compounds 2, 1 and 4 (each within the scatter of the next); then compound 3.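

In this assay, the 2-methoxyphenyl group is not set apart from either 4-substituted phenyl group: the result is a 1.1-fold higher number from compound 1 to compound 4 (0.03 log units; within the scatter) and a 1.2-fold higher number from compound 2 to compound 4 (0.08 log units; within the scatter). The exchange of chloro for methoxy gives a 6.5-fold lower number from compound 3 to compound 4 (0.81 log units; beyond the scatter), so the weak growth inhibition of compound 3 does not extend to every 2-substituted phenyl group in this place. No measurement shown here explains the gap between methoxy and chloro. As far as these compounds go, whether an ethoxy, a hydroxy or a fluoro group in place of the methoxy would follow compound 4 or compound 3 remains open.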